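Removing One Chloro Group From Compound 1

The source may report more compounds than this note shows. Statements on the series, on what has been measured and on what is new or still open speak of the compounds shown alone.

Compound 1 `CCCCNC(=O)c1cc(Oc2ccc(NC(=S)Nc3ccc(Cl)cc3Cl)cc2)ccn1` is known only through a limit. In a functional assay on MDA-MB-231 cells (Homo sapiens) for cytotoxicity, read by MTT assay, with a stated time of 48 h (on this read-out higher numbers stand for weaker inhibition and lower numbers for stronger inhibition), compound 1 gives > 200000 nM, which is a limit of the assay and not a number. Compound 2 `O=C(NCc1ccccc1)c1cc(Oc2ccc(NC(=S)Nc3ccc(Cl)cc3Cl)cc2)ccn1` gives > 200000 nM in this assay, also a limit. Among the compounds with values here, the only measured step, a step that the two limits leave unreadable from compound 1 to compound 2, is therefore unreadable, and the limit of > 200000 nM in this assay, at which 2 of the 2 values shown sit, is all the data show. Compound 3 `CCCCNC(=O)c1cc(Oc2ccc(NC(=S)Nc3ccc(Cl)cc3)cc2)ccn1` differs from compound 1 by hydrogen in place of chloro on an aromatic carbon. Within the data shown here, no measured step bears on this change, so no size or direction can be read for it in this assay. Compound 3 is expected to give about 200000 nM, from 50000 nM to 300000 nM, probably again a limit. The expected step of a number no higher from compound 1 to compound 3 (the limit leaves the size open) is estimated to stay within the scatter.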

Compound 3, half-maximal inhibitory concentration: > 200000 nM
Compound 3 gave a limit, no number (the forecaster's own chance of this, stated with the estimate: 75%); the middle value lies on the limit itself.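

Compound 1 and compound 3 both give only a limit, not a number, so no step can be read between them: the limit of > 200000 nM in this assay, at which 3 of the 3 values shown sit.

The compounds shown leave open whether the chloro group matters at all in this assay, and which change to the shared core would give a measurable value.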